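Thioether substituent variation on the shared core

The compounds below may be only part of what the source reports. "The series", "measured", "known", "first", "only" and "open" are said of these compounds alone.

Measured compounds:
- compound 1 `CC(C)CCSc1nc(C(F)(F)F)ccc1CNC(=O)C(C)c1ccc(NS(C)(=O)=O)c(F)c1`: 82 nM
- compound 2 `CC(C(=O)NCc1ccc(C(F)(F)F)nc1SCCCN1CCCCC1)c1ccc(NS(C)(=O)=O)c(F)c1`: 250 nM
- compound 3 `COC(=O)CCSc1nc(C(F)(F)F)ccc1CNC(=O)C(C)c1ccc(NS(C)(=O)=O)c(F)c1`: 1100 nM

In an assay on CHO-K1 cells for antagonist activity at transient receptor potential cation channel subfamily V member 1 (Homo sapiens), read by FLIPR (a higher number here means a weaker inhibitor, a lower number a stronger inhibitor), compound 1 gives the lowest number of the three. The nearest is compound 2, reached by a 3.0-fold higher number from compound 1 to compound 2 (0.48 log units; beyond the scatter); the furthest is compound 3, reached by a 13-fold higher number from compound 1 to compound 3 (1.13 log units; beyond the scatter). Between those two, a 4.4-fold higher number from compound 2 to compound 3 (0.64 log units; beyond the scatter).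

Compound 4 `CC1CCC(Sc2nc(C(F)(F)F)ccc2CNC(=O)C(C)c2ccc(NS(C)(=O)=O)c(F)c2)CC1` is not yet measured. It differs from compound 1 in one place: 4-methylcyclohexyl in place of isopentyl on a sulfur. The group on the sulfur stays carbon only, with no hydrogen-bond donors or acceptors, as in compound 1.

Among the measured compounds shown here, none of the measured steps makes this exact change. All three replace the isopropyl end of the chain with a group carrying heteroatoms, and every such replacement gave a higher number, the largest with the methoxycarbonyl of compound 3. The change to compound 4 introduces no heteroatom and adds two carbons while closing a ring, so those steps bear on it only indirectly. The expectation for compound 4 is therefore a number close to that of compound 1, with any step, up or down, staying within or only slightly beyond the scatter.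

For compound 4 the estimate is 110 nM, within 40 nM to 320 nM, which means an expected step of a 1.3-fold higher number from compound 1 to compound 4 (0.13 log units; within the scatter).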

Compound 4, half-maximal inhibitory concentration: 180 nM
Compound 4: the middle estimate sits 1.6-fold (0.21 log units) below what was measured, and the stated range covers the measured number.
By their numbers in this assay, from the lowest: compound 1; then compounds 4 and 2 (each within the scatter of the next); then compound 3.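

In this assay, among the compounds shown here, the earlier steps all put heteroatoms on the end of the thioether chain, whereas compound 4 shows that a carbon-only group with no hydrogen-bond donors or acceptors can also give a higher number than isopentyl (a 2.2-fold higher number from compound 1 to compound 4 (0.34 log units; beyond the scatter)), so compound 1 remains the lowest of the four. The 4-methylcyclohexyl group still keeps a clear margin over the 2-(methoxycarbonyl)ethyl group (a 6.1-fold lower number from compound 3 to compound 4 (0.79 log units; beyond the scatter)), so the group on the sulfur continues to separate these compounds. Against the 3-(piperidin-1-yl)propyl group the step stays within the scatter (a 1.4-fold lower number from compound 2 to compound 4 (0.14 log units; within the scatter)), which means a carbon-only ring and a chain ending in piperidine cannot be told apart at this position, and no supporting measurement bears on any of these steps.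

The change to compound 4 closes a ring and adds carbons in one move, so the effect of each remains unresolved; unsubstituted cyclohexyl and a straight heptyl chain would separate the two. On these data alone, it also remains open how a carboxylic acid in place of the methoxycarbonyl, or a phenyl ring on the sulfur, would compare with isopentyl.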